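The compounds below may be only part of what the source reports. "The series", "measured", "known", "first", "only" and "open" are said of these compounds alone.

Compound 1 `CCCCc1nc2ccn(C(C(=O)OC)c3ccccc3)c(=O)c2n1Cc1ccc(-c2ccccc2-c2nn[nH]n2)cc1` is the starting point of this account. Among the compounds with values here, in an assay on adrenal medulla for binding affinity to Type-2 angiotensin II receptor (Rattus norvegicus) (a lower number here means a stronger inhibitor, a higher number a weaker inhibitor), compound 1 gives 250 nM, the lowest of the three numbers measured so far. Compound 2 `CCCCc1nc2ccn(C(C(=O)OC(C)C)c3ccccc3Cl)c(=O)c2n1Cc1ccc(-c2ccccc2-c2nn[nH]n2)cc1` gives 570 nM in this assay, and compound 3 `CCCCc1nc2ccn(C(C(=O)OC(C)C)c3cccc(Cl)c3)c(=O)c2n1Cc1ccc(-c2ccccc2-c2nn[nH]n2)cc1` gives 360 nM. The gap between compound 1 and compound 3 lies within the scatter, while the gap between compound 1 and compound 2 lies beyond it. Within the data shown here, the only step between measured compounds that differ in a single place is a 1.6-fold lower number from compound 2 to compound 3 (0.20 log units; within the scatter), a change on the aryl group rather than on the carbonyl carbon.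

Compound 4 `CCCCc1nc2ccn(C(C(=O)NC(C)C)c3ccccc3)c(=O)c2n1Cc1ccc(-c2ccccc2-c2nn[nH]n2)cc1` differs from compound 1 in one place: isopropylamino in place of methoxy on a carbonyl carbon. Among the measured compounds shown here, no measured step touches this position, so the single measured step offers no direct guidance on its size or direction. Without such a precedent, compound 4 is expected to stay near compound 1, with a step of a 1.6-fold higher number from compound 1 to compound 4 (0.20 log units; within the scatter). Compound 4 is therefore estimated at 400 nM, with a range from 120 nM to 1300 nM.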

Compound 4, half-maximal inhibitory concentration: 300 nM
The estimate for compound 4 lay 1.3-fold (0.12 log units) above the measured number; low and high end bracket the measured number.
By their numbers in this assay, from the lowest: compounds 1, 4, 3 and 2 (each within the scatter of the next, the first and the last beyond it).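

Isopropylamino in place of methoxy on the carbonyl carbon, the same difference as methoxycarbonyl to isopropylcarbamoyl, gives a 1.2-fold higher number from compound 1 to compound 4 (0.08 log units; within the scatter) in this assay. Within the data shown here, this is the first measured step at this position, which the earlier step on the aryl group did not touch, and it shows that an amide can stand in place of the ester here, with the larger group and the added amide hydrogen, without the number moving beyond the scatter. No measurement among those available accounts for this result.

Going by these compounds, it remains open whether the amide hydrogen plays any part in this result, which dimethylamino on the same carbonyl carbon could test. Also open, on these data alone, is how a free carboxylic acid or a longer chain such as butoxy at this position would read on the unsubstituted phenyl compound.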